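Methylating the oxime in a second core: cytotoxicity outlook

This account rests on a few compounds, and the source may have more. Where it says the series, first, only, none or still open, it means among the compounds named here.

Compound 1 `CON=C1CCC(CN2CCN(c3nc(=O)c4cc(C(F)(F)F)cc([N+](=O)[O-])c4s3)C[C@H]2C)CC1` and compound 2 `CCON=C1CCC(CN2CCN(c3nc(=O)c4cc(C(F)(F)F)cc([N+](=O)[O-])c4s3)C[C@H]2C)CC1` share one core; compound 3 `CON=C1CCC(CN2CCN(c3nc(=O)c4cc(C(F)(F)F)cc([N+](=O)[O-])c4s3)[C@@H](C)C2)CC1` and compound 4 `CCON=C1CCC(CN2CCN(c3nc(=O)c4cc(C(F)(F)F)cc([N+](=O)[O-])c4s3)[C@@H](C)C2)CC1` share another, and the difference between the two cores is not broken down here. In an ADME assay on Vero cells (Chlorocebus sabaeus) for cytotoxicity (a higher number here means that more compound is tolerated, a lower number that less compound is tolerated), compound 1 reaches only the limit > 64 ug/mL. Compound 2 likewise sits at the limit > 64 ug/mL. Compound 3 also gives only the limit > 64 ug/mL. The change from compound 1 to compound 2 is methyl in place of hydrogen on a saturated chain carbon bound to an oxygen on an unsaturated carbon, and the same change from compound 3 to compound 4 is methyl in place of hydrogen on a saturated chain carbon bound to an oxygen on an unsaturated carbon, with both place descriptions identical. Because of the limit of > 64 ug/mL in this assay, at which 3 of the 3 values shown sit, the step that the two limits leave unreadable from compound 1 to compound 2 cannot be read as a number, so it only shows that tolerance stayed beyond what this assay measures. On that basis the step from compound 3 to compound 4 is expected to be small, estimated as a step that the limit leaves unreadable from compound 3 to compound 4, resting on compound 2 holding the limit > 64 ug/mL. For compound 4 the estimated value is 90 ug/mL, most likely again reported only as a limit.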

Compound 4, half-maximal cytotoxic concentration: > 64 ug/mL
Compound 4 gave a limit, no number; the forecaster's own chance of this, stated with the estimate: 85%; the middle value lies beyond the limit too.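

No size can be read for the change from methoxy to ethoxy between compound 3 and compound 4, because both results are limits rather than numbers: the limit of > 64 ug/mL in this assay, at which 4 of the 4 values shown sit. The compounds shown leave open where the true values in this assay lie, and so whether the added methyl changes tolerance at all in either core.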